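Two paw-edema results, one methoxy removed

The source may hold more compounds than are shown below. What is called first, only, known or untested is meant among the compounds shown, and "the series" means these compounds.

Measured so far:
compound 1 `COc1ccc(C2=NNC(c3c(Cl)cccc3Cl)C2)cc1` — 58%
compound 2 `COc1ccc(C2=NN(C(=O)CBr)C(c3c(Cl)cccc3Cl)C2)cc1OC` — 58%

In a functional assay on the whole organism (strain albino) for inhibition, with Rattus norvegicus as the target, read by paw edema, with stated times of 30 min and 2 h, at a dose of 100 mg/kg by the oral route (a lower number here means less inhibition, a higher number more inhibition at the dose given (going by the name of the read-out)), compound 1 gives 58% and compound 2 gives 58%; compound 2 stands level with compound 1 at the digits shown, and the two values lie within the usual scatter of repeated measurements. For the measured compounds named here, the series therefore holds one pair of compounds that differ in more than one place and no single-point step between measured compounds, so nothing about the effect of any one change has been read yet.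

Compound 3 `COc1ccc(C2=NN(C(=O)CBr)C(c3c(Cl)cccc3Cl)C2)cc1` is next, and it sits one place away from compound 2: hydrogen in place of methoxy on an aromatic carbon. The methoxy leaves from an aromatic carbon of a six-membered aromatic ring of carbon only, ortho to a methoxy group, and hydrogen enters in its place. Going by the values given here, no measured step reports what removing a methoxy does in this assay, and the two numbers so far sit where compound 2 sits. The expectation for compound 3 in this assay is a step of a number 2 percentage points lower from compound 2 to compound 3 (within the scatter), essentially none beyond the scatter. Compound 3 is thus estimated at 56%, with a range of 44% to 68%.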

Compound 3, a percentage reported as inhibition, in the whole organism at one dose (the size of the read-out at that dose, not a potency): 49%
The estimate for compound 3 lay 7 percentage points above the measured number, and the stated range covers the measured number.
By their numbers in this assay, from the lowest: compounds 3, 1 and 2 (each within the scatter of the next).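

In this assay, the series now has its first single-place readings: hydrogen in place of methoxy on an aromatic carbon, ortho to a methoxy group, gives a number 9 percentage points lower from compound 2 to compound 3 (within the scatter), so this read-out does not separate the two substituents at this position. At the second place, (bromomethyl)carbonyl in place of hydrogen on an amine nitrogen in a ring gives a number 9 percentage points lower from compound 1 to compound 3 (within the scatter), so this read-out does not separate that group from hydrogen on the nitrogen either. No measurement at hand bears on the reason for either result.

On these data alone, whether a hydroxy group, or a longer chain such as ethoxy, on that aromatic carbon would give a step beyond the scatter remains open, as does the outcome with an acetyl or aminoacetyl group on the ring nitrogen. These readings also come from a single oral dose, so they leave open whether compound 1, compound 2 and compound 3 would stay within the scatter of one another at other doses.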